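Dropping one methoxy from the dimethoxybenzyl end

The source may report more compounds than this note shows. Statements on the series, on what has been measured and on what is new or still open speak of the compounds shown alone.

Two sulfonamide-linked benzylamines have been measured so far in a functional assay on MIA PaCa-2 cells (Homo sapiens) for inhibition, read by MTT assay, with a stated time of 72 h; on this read-out higher numbers stand for weaker inhibition of growth and lower numbers for stronger inhibition of growth. Compound 1 `COc1ccc(CNCCCNS(=O)(=O)c2cc(C(F)(F)F)cc(C(F)(F)F)c2)cc1OC` gives 2800 nM in this assay. Compound 2 `O=S(=O)(NCCCCCCNCc1ccc(Br)cc1)c1c(Cl)cc(C(F)(F)F)cc1Cl` gives 5670 nM in this assay. Of these two numbers, compound 1 stands lowest; its nearest neighbour is compound 2, whose number lies higher by a margin beyond the usual scatter. Going by the values given here, no pair among the measured compounds differs in only one place, so no measured step exists to lean on.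

Compound 3 `COc1ccc(CNCCCNS(=O)(=O)c2cc(C(F)(F)F)cc(C(F)(F)F)c2)cc1` has not yet been measured. It differs from compound 1 in a single spot: hydrogen in place of methoxy on an aromatic carbon The change sits on an aromatic carbon of a six-membered aromatic ring of carbon only, ortho to a methoxy group and meta to a large group, so the 3,4-dimethoxybenzyl of compound 1 becomes a 4-methoxybenzyl.

With nothing measured to anchor the step, the author expects a 1.3-fold higher number from compound 1 to compound 3 (0.10 log units; within the scatter) to be small, most likely within the scatter or a modest rise. For compound 3 the expected value is 3500 nM, estimated to fall between 1500 nM and 8000 nM.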

Compound 3, concentration for 50% growth inhibition: 2500 nM
Estimate against measurement, compound 3: 1.4-fold (0.15 log units) above; the measured number falls inside the stated range.
By their numbers in this assay, from the lowest: compounds 3 and 1 (each within the scatter of the next); then compound 2.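

Going by these compounds alone, measured in this assay there is now a 1.1-fold lower number from compound 1 to compound 3 (0.05 log units; within the scatter) when hydrogen replaces the methoxy on this aromatic carbon, the first comparison that differs in only one place. The earlier compounds shown here could not isolate any single position, whereas this pair shows that, on the shared core of compound 1 and compound 3, the read-out does not distinguish the 3,4-dimethoxybenzyl from the 4-methoxybenzyl. At this carbon, ortho to a methoxy group and meta to a large group, the methoxy is therefore not required to keep growth inhibition at the level seen for compound 1, though no measurement of any property of these compounds accounts for this result.

The compounds shown leave open whether other replacements at this carbon, such as a hydroxyl, a fluorine, a chlorine or an ethoxy, would also leave the read-out unchanged, and whether the remaining methoxy can be replaced by hydrogen in the same way. They also leave open whether the same exchange would behave alike with a longer chain in the linker or with another substitution pattern on the sulfonyl-bearing ring.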